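The source may report more compounds than this note shows. Statements on the series, on what has been measured and on what is new or still open speak of the compounds shown alone.

Compound 1 `COc1cc(/C=C2\CNC/C(=C\c3cc(OC)c(OC)c(OC)c3)C2=O)cc(OC)c1OC` gives 4000 nM in a functional assay on NCI-H1975 cells (Homo sapiens) for cytotoxicity, read by MTT assay, with a stated time of 72 h; on this read-out lower numbers stand for stronger inhibition and higher numbers for weaker inhibition.
Compound 2 `COc1cc(/C=C2\CN(C)C/C(=C\c3cc(OC)c(OC)c(OC)c3)C2=O)cc(OC)c1OC` gives 1000 nM.
Compound 3 `CCC(=O)N1C/C(=C\c2cc(OC)c(OC)c(OC)c2)C(=O)/C(=C/c2cc(OC)c(OC)c(OC)c2)C1` gives 1700 nM.

On these numbers compound 3 stands second highest of the three. Compound 2 lies nearest to it, with a 1.7-fold higher number from compound 2 to compound 3 (0.23 log units; within the scatter); compound 1 lies furthest, with a 2.4-fold lower number from compound 1 to compound 3 (0.37 log units; beyond the scatter).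

Compound 4 `COc1cc(/C=C2\CN(C(=O)c3ccccc3F)C/C(=C\c3cc(OC)c(OC)c(OC)c3)C2=O)cc(OC)c1OC` differs from compound 3 in one place: 2-fluorophenyl in place of ethyl on a carbonyl carbon.

Of the measured steps, a 4.0-fold lower number from compound 1 to compound 2 (0.60 log units; beyond the scatter) and a 2.4-fold lower number from compound 1 to compound 3 (0.37 log units; beyond the scatter) both replace the hydrogen on the ring nitrogen, and a 1.7-fold higher number from compound 2 to compound 3 (0.23 log units; within the scatter) exchanges methyl for propanoyl at that same nitrogen. Within the data shown here, none of them alters what sits on the carbonyl carbon, so no measured step bears directly on the change to compound 4, and the three steps themselves are modest or within the scatter. The expectation is therefore a step of no clear direction: a 1.1-fold lower number from compound 3 to compound 4 (0.05 log units; within the scatter) is the estimated step. Compound 4 is expected to give 1500 nM, within a range from 500 nM to 5000 nM.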

Compound 4, half-maximal inhibitory concentration: 1400 nM
Compound 4: the middle estimate sits 1.1-fold (0.03 log units) above what was measured; low and high end bracket the measured number.
By their numbers in this assay, from the lowest: compounds 2, 4 and 3 (each within the scatter of the next); then compound 1.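

In this assay, 2-fluorophenyl in place of ethyl on the carbonyl carbon adds a six-membered aromatic ring, yet the change stays within the scatter (a 1.2-fold lower number from compound 3 to compound 4 (0.08 log units; within the scatter)). The position thus tolerates this larger group with no readable change, and the (2-fluorophenyl)carbonyl group likewise cannot be told apart from methyl on the ring nitrogen (a 1.4-fold higher number from compound 2 to compound 4 (0.15 log units; within the scatter)), while it keeps a modest edge over hydrogen there (a 2.9-fold lower number from compound 1 to compound 4 (0.46 log units; beyond the scatter)). Nothing measured here offers an explanation for this flat response.

The compounds shown leave open whether the fluorine contributes anything, and whether a plain phenyl, a longer chain or an amine on the carbonyl carbon would stay in this range. They also leave open whether any other group on the ring nitrogen could move the number further.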